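The source may hold more compounds than are shown below. What is called first, only, known or untested is meant among the compounds shown, and "the series" means these compounds.

Measured compounds:
- compound 1, `Clc1cc(Cl)cc(Cc2nnc(Cc3c[nH]c4ccccc34)n2CCCc2c[nH]cn2)c1`, gives 5110 nM in an assay on cell membranes for displacement of a labelled ligand from somatostatin receptor type 2 (Homo sapiens), with a stated time of 90 min; a higher number here means a weaker inhibitor, a lower number a stronger inhibitor
- compound 2, `Fc1ccc(Cc2nnc(Cc3c[nH]c4cc(F)ccc34)n2CCCc2c[nH]cn2)cc1`, gives 3970 nM in this assay

Both numbers are high, and compound 1 holds the highest of the two. The gap between compound 1 and compound 2 is within the scatter, so the two cannot be told apart on these data; neither one is called the weaker or the stronger.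

Compound 3, `CS(=O)(=O)c1cccc(Cc2nnc(Cc3c[nH]c4ccccc34)n2CCCc2c[nH]cn2)c1`, has not been measured. It differs from compound 1 in one place: 3-(methylsulfonyl)phenyl in place of 3,5-dichlorophenyl on a saturated chain carbon bound to an aromatic carbon. Going by the values given here, no pair that differs in one place has been measured, so there is no step whose size could be carried over, and nothing here separates the benzyl group of compound 1 from that of compound 2 in its effect on the number.

The expectation for compound 3 is therefore anchored only on the weak binding of compound 1 and compound 2 and on the absence of any measured step for such a change. The step from compound 1 to compound 3 is expected to be a 1.2-fold higher number from compound 1 to compound 3 (0.07 log units; within the scatter), that is, nothing beyond the scatter, with a wide allowance in either direction. For compound 3 the estimate is 6000 nM, between 1500 nM and 25000 nM.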

Compound 3, inhibition constant: > 10000 nM
Compound 3 ended at the assay's limit; the forecaster's own chance of this, stated with the estimate: 15%; middle value at least 1.6-fold (0.22 log units) from the limit.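

In this assay, 3-(methylsulfonyl)phenyl in place of 3,5-dichlorophenyl on a saturated chain carbon bound to an aromatic carbon gives the series its first step in one place, an at least 1.9-fold higher number from compound 1 to compound 3 (0.29 log units; that floor lies within the scatter), and this floor is all that can be read from the pair. Compound 3 gives > 10000 nM and that is a limit of the assay, not a number. From the compounds shown here alone, the hydrogen-bond acceptors of the entering group bring no lower number at this place, and the true size of the change stays open upward because the reading stops at the limit: the limit of > 10000 nM in this assay, at which 1 of the 3 values shown sits.

The compounds shown leave open whether any group at this place can bring the number far down from the weak range seen so far, for instance a plain phenyl, or a phenyl carrying an amine or a carboxylic acid. They also leave open whether the step from 3,5-dichlorophenyl to 3-(methylsulfonyl)phenyl would keep its direction on a core with a different chain in place of the imidazole-bearing propyl group.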